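This account rests on a few compounds, and the source may have more. Where it says the series, first, only, none or still open, it means among the compounds named here.

Measured compounds in the series:
compound 1 `COc1ccc(/C=C/c2cc(OC)cc(OC)c2/C=C/C(=O)c2ccccc2)cc1`, 3.7 ug/mL
compound 2 `CCCCCCOc1ccc(C(=O)/C=C/c2c(/C=C/c3ccc(OC)cc3)cc(OC)cc2OC)cc1`, 10.4 ug/mL
compound 3 `COc1ccc(/C=C/c2cc(OC)cc(OC)c2/C=C/C(=O)c2ccc(Cl)c(Cl)c2)cc1`, 7.5 ug/mL

All three were read in a functional assay on B16-F10 cells (Mus musculus) for antiproliferative activity, read by MTT assay, with a stated time of 48 h; a higher number here means a weaker inhibitor, a lower number a stronger inhibitor. Compound 3 stands second highest of the three numbers; its nearest neighbour is compound 2, within the scatter, while compound 1 lies beyond the scatter below it, as a 2.0-fold higher number from compound 1 to compound 3 (0.31 log units; beyond the scatter) shows. Compound 4 `COc1ccc(/C=C/c2cc(OC)cc(OC)c2/C=C/C(=O)c2ccccc2C)cc1` differs from compound 3 only at the carbonyl carbon: 2-methylphenyl in place of 3,4-dichlorophenyl on a carbonyl carbon. Among the compounds with values here, no measured step carries the 2-methylphenyl group. Within the data shown here, the one step that bears on the place is a 2.0-fold higher number from compound 1 to compound 3 (0.31 log units; beyond the scatter), a modest rise on going from phenyl to 3,4-dichlorophenyl; the hexyloxy step a 2.8-fold higher number from compound 1 to compound 2 (0.45 log units; beyond the scatter) concerns another position. Since 2-methylphenyl resembles phenyl more than 3,4-dichlorophenyl, compound 4 is expected to give a number somewhat lower than compound 3, a step of a 1.7-fold lower number from compound 3 to compound 4 (0.22 log units; within the scatter). The estimate for compound 4 in this assay is 4.5 ug/mL, with a range from 2.2 ug/mL to 9.5 ug/mL.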

Compound 4, half-maximal inhibitory concentration: 6.1 ug/mL
Compound 4: the middle estimate sits 1.4-fold (0.13 log units) below what was measured, and the stated range covers the measured number.
By their numbers in this assay, from the lowest: compounds 1, 4, 3 and 2 (each within the scatter of the next, the first and the last beyond it).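

In this assay the carbonyl carbon now has a third aromatic group to compare, and a 1.2-fold lower number from compound 3 to compound 4 (0.09 log units; within the scatter) and a 1.6-fold higher number from compound 1 to compound 4 (0.22 log units; within the scatter) are both within the scatter. 2-Methylphenyl therefore cannot be told apart from either phenyl or 3,4-dichlorophenyl, even though those two groups differ from each other beyond the scatter. Nothing available explains this result.

Still open, as far as these compounds go, is how a ring bearing an amine or a carboxylic acid would read on a carbonyl carbon. Also open, from the compounds shown here alone, is whether a longer chain in place of the methyl would separate from phenyl.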